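A few compounds are considered here, and "the series" means these few. Any claim that something is new, unique, unknown or untested is made for them only; others in the source may bear on it.

Working notes on the series. For the measured compounds named here, in a functional assay on NCI-H322M cells (Homo sapiens) for inhibition, read by sulforhodamine B assay, with a stated time of 48 h (on this read-out higher numbers stand for weaker inhibition of growth and lower numbers for stronger inhibition of growth), compound 1 `COc1ccc(CNc2nc3cc(N)cc(N)c3nc2-c2ccccc2)cc1OC` gives 22900 nM and compound 2 `Nc1cc(N)c2nc(-c3ccccc3)c(NCc3ccc(F)cc3)nc2c1` gives 3470 nM, the lower of the two numbers, with a 6.6-fold lower number from compound 1 to compound 2 (0.82 log units; beyond the scatter) as the only measured step. Compound 3 `Nc1cc(N)c2nc(-c3ccccc3)c(Sc3ccc(F)cc3)nc2c1` differs from compound 2 by (4-fluorophenyl)sulfanyl in place of (4-fluorobenzyl)amino on an aromatic carbon. Going by the values given here, the step from compound 1 to compound 2 changed the ring on the saturated chain carbon, not the linker, so no measured step bears on this change. Compound 3 is therefore estimated near 8000 nM (range 2000 nM to 30000 nM). The expected step is a 2.3-fold higher number from compound 2 to compound 3 (0.36 log units; beyond the scatter), wide in uncertainty.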

Compound 3, concentration for 50% growth inhibition: 20400 nM
For compound 3 the middle estimate is 2.6-fold (0.41 log units) below the measured one; low and high end bracket the measured number.
By their numbers in this assay, from the lowest: compound 2; then compounds 3 and 1 (each within the scatter of the next).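

In this assay, (4-fluorophenyl)sulfanyl in place of (4-fluorobenzyl)amino on this aromatic carbon gives a 5.9-fold higher number from compound 2 to compound 3 (0.77 log units; beyond the scatter), so the linker matters here as well as the ring it carries. For the compounds shown here, this is the first measured step at the linker, and it keeps the 4-fluorophenyl ring while the hydrogen-bond donor is lost. Nothing available explains the size of this step.

The compounds shown leave open whether the sulfur or the shorter linker accounts for the step. A (4-fluorophenyl)amino or (4-fluorobenzyl)sulfanyl group on this carbon would separate the two.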